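The compounds below may be only part of what the source reports. "The series", "measured", "known", "first", "only" and "open" are said of these compounds alone.

Two measured compounds frame this account. Compound 1 `COc1ccccc1/C=C/C(=O)c1cc(NC(C)=O)ccc1O` was tested in an ADME assay on MT4 cells (Homo sapiens) for cytotoxicity, read by MTT assay, with a stated time of 4 days (a lower number here means that less compound is tolerated, a higher number that more compound is tolerated), and in that assay compound 1 gives 37800 nM. Compound 2 `COc1ccc(-c2cc(=O)c3cc(NC(C)=O)ccc3o2)cc1` is built on a different core; in this assay compound 2 gives 226000 nM. Of the two numbers in this assay, compound 2 stands highest, with compound 1 as its nearest neighbour, whose number is lower by a margin beyond the usual scatter. The unmeasured compound 3 `CC(=O)Nc1ccc2oc(-c3ccc(F)cc3)cc(=O)c2c1` keeps the core of compound 2 and differs from it in one place: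

fluoro in place of methoxy on an aromatic carbon

Among the compounds with values here, no step between two measured compounds bears on this exchange, so the measured numbers give no direct guide to its size. The account expects the step from compound 2 to compound 3 in this assay to be small, a 1.5-fold lower number from compound 2 to compound 3 (0.18 log units; within the scatter), a modest move toward a lower number that may well sit within the scatter. Compound 3 is therefore estimated at 150000 nM in this assay, within a range of 60000 nM to 400000 nM.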

Compound 3, half-maximal cytotoxic concentration: 203000 nM
Compound 3: middle estimate off by 1.4-fold (0.13 log units), on the low side; low and high end bracket the measured number.
By their numbers in this assay, from the lowest: compound 1; then compounds 3 and 2 (each within the scatter of the next).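

In this assay, within the data shown here, fluoro in place of methoxy on an aromatic carbon, para to a large group, gives a 1.1-fold lower number from compound 2 to compound 3 (0.05 log units; within the scatter) and so provides the first measured step at this position. The two compounds cannot be told apart in this assay, even though the change removes the methoxy group's two heavy atoms and its hydrogen-bond acceptor and brings in a single fluorine. This reading holds only for this one exchange on this one core, and no supporting measurement accounts for it.

From the compounds shown here alone, it remains open whether an amine, a hydroxyl, a chloro group or a longer alkoxy chain on the same aromatic carbon would also leave the number in this assay within the scatter of compound 2. Also open, going by these compounds, is whether the exchange of methoxy for fluoro would read the same way on the core of compound 1, where the methoxy group occupies a different place, or on a version of the shared core carrying a carboxylic acid in place of the acetyl amide.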